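The compounds below may be only part of what the source reports. "The series", "measured", "known", "first", "only" and "open" are said of these compounds alone.

The three measured compounds, all tested in an in vitro functional assay on cells for agonist activity at Bombesin receptor subtype-3 (Homo sapiens), read by luminescence and calcium flux; on this read-out higher numbers stand for an effect only at larger amounts of compound and lower numbers for an effect already at smaller amounts:

Compound 1, `CCCCc1cnc(C(C)Cc2ccc(-c3ccccc3C(=O)O)cc2)[nH]1`, gives 2760 nM.
Compound 2, `CCCCc1cnc(C(CCCC)Cc2ccc(-c3ccccc3C(=O)O)cc2)[nH]1`, gives 2660 nM.
Compound 3, `CCCCc1cnc(CCc2ccc(-c3ccccc3C(=O)O)cc2)[nH]1`, gives 2710 nM.

Compound 3 sits second highest of these three numbers, yet its neighbours are so close that nothing separates them: the step of a 1.0-fold lower number from compound 1 to compound 3 (0.01 log units; within the scatter) and the step of a 1.0-fold higher number from compound 2 to compound 3 (0.01 log units; within the scatter) both stay within the scatter, as does the step of a 1.0-fold lower number from compound 1 to compound 2 (0.02 log units; within the scatter). Those three steps all touch the chain that links the shared core of compound 3 to its biphenyl acid side, and the number barely moves whatever sits there.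

Within the data shown here, compound 4, `O=C(O)c1ccccc1-c1ccc(CCc2ncc(Cc3cccc(Cl)c3)[nH]2)cc1`, changes a different place. 3-chlorophenyl in place of propyl on a saturated chain carbon bound to an aromatic carbon This alters the group hanging off the core itself, a site none of the measured steps has probed. The measured series therefore gives no direct guidance for the size or direction of this change; it shows only that the assay tolerated variation elsewhere without moving beyond the scatter. With nothing pointing either way, the expected step of a 1.0-fold lower number from compound 3 to compound 4 (0.00 log units; within the scatter) is set at no change, with a wide band of uncertainty. Compound 4 is thus estimated at 2700 nM, between 600 nM and 12000 nM.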

Compound 4, half-maximal effective concentration: 825 nM
Beside the measured number, compound 4's estimate is 3.3-fold (0.51 log units) above it; the measured number falls inside the stated range.
By their numbers in this assay, from the lowest: compound 4; then compounds 2, 3 and 1 (each within the scatter of the next).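

In this assay, the group at this position, on a saturated chain carbon bound to an aromatic carbon, does move the number: replacing propyl with 3-chlorophenyl gives a 3.3-fold lower number from compound 3 to compound 4 (0.52 log units; beyond the scatter). This modest step is the only one in the set that lies beyond the scatter, so this site responds where changes to the chain linking the core to the biphenyl acid side did not, and the lower number means an effect already at smaller amounts of compound. The change brings in an aromatic ring and a chlorine together, with no hydrogen-bond donors or acceptors on either side of the swap, and no supporting measurement here explains the shift.

A plain phenyl group without the chlorine, or a fluorine or methoxy group in the chlorine's place, would help show whether the ring alone or the chlorine on it goes with the lower number. From the compounds shown here alone, it also remains open whether the linking chain would still tolerate a methyl or butyl group with 3-chlorophenyl present, as it did with the propyl-bearing compounds.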